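Working notes on the step to compound 3

This account rests on a few compounds, and the source may have more. Where it says the series, first, only, none or still open, it means among the compounds named here.

Values in a physicochemical assay for solubility, read by LC-MS, in phosphate buffer, with a stated time of 24 h, at pH 7.4; on this read-out higher numbers stand for higher solubility and lower numbers for lower solubility:
- compound 1 `CN(C)C(=O)c1cc(-c2cnc(NCc3c(F)ccc4c3CCO4)c3cn[nH]c(=O)c23)n(C)n1`: 3000 nM
- compound 2 `Cc1ncccc1-c1cnc(NCc2c(F)ccc3c2CCO3)c2cn[nH]c(=O)c12`: < 2000 nM (a limit)

Compound 2 has no number of its own, only (the limit of < 2000 nM in this assay, at which 1 of the 2 values shown sits). Its place in this assay is therefore open downward.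

Compound 3 `CNC(=O)c1ncc(-c2cnc(NCc3c(F)ccc4c3CCO4)c3cn[nH]c(=O)c23)n1C` is not yet measured. Its structural change is 1-methyl-2-(methylcarbamoyl)-1H-imidazol-5-yl in place of 2-methylpyridin-3-yl on an aromatic carbon, with 1-methyl-2-(methylcarbamoyl)-1H-imidazol-5-yl in place of 2-methylpyridin-3-yl on an aromatic carbon of the shared core.

For the measured compounds named here, one measured step bears on this: an at least 1.5-fold lower number from compound 1 to compound 2 (0.17 log units; that floor lies within the scatter). It removes a carbamoyl-bearing five-membered aromatic ring and brings in 2-methylpyridin-3-yl, while the step now in question does the opposite with a different carbamoyl-bearing ring. The two rings are not the same, so that step is a weak guide, and its size is known only as a floor. On the strength of compound 1 at 3000 nM, a modest upward move is expected, not clearly beyond the scatter. A second limit remains possible.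

The expected step is an at least 1.5-fold higher number from compound 2 to compound 3 (0.17 log units; that floor lies within the scatter).

For compound 3 the estimate is 3000 nM, with an expected range of 1000 nM to 10000 nM.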

Compound 3, solubility: 5000 nM
The estimate for compound 3 lay 1.7-fold (0.22 log units) below the measured number; the range from low to high includes it.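

On the aromatic carbon of the shared core, this assay now gives a step beyond the scatter for 1-methyl-2-(methylcarbamoyl)-1H-imidazol-5-yl in place of 2-methylpyridin-3-yl: an at least 2.5-fold higher number from compound 2 to compound 3 (0.39 log units; beyond the scatter). The earlier step between a carbamoyl-bearing ring and 2-methylpyridin-3-yl had only a floor within the scatter, and the size of this new step is likewise a floor, not a measured gap: the limit of < 2000 nM in this assay, at which 1 of the 3 values shown sits.

The two carbamoyl-bearing five-membered rings are not told apart at this position, with a 1.7-fold higher number from compound 1 to compound 3 (0.22 log units; within the scatter), so 1-methyl-2-(methylcarbamoyl)-1H-imidazol-5-yl and 3-(dimethylcarbamoyl)-1-methyl-1H-pyrazol-5-yl read as equal in this assay.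

Still open is which part of the entering group goes with the step, given that the ring and the carbamoyl change together in every comparison shown. The same five-membered ring carrying a carboxylic acid or an amine in place of the methylcarbamoyl would bear on that question, and the compounds shown say nothing about either group.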